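A few compounds are considered here, and "the series" means these few. Any claim that something is new, unique, unknown or untested is made for them only; others in the source may bear on it.

Compound 1 `CC(C)[C@@H]1CC[C@@H](C)C[C@@]12N(C)C(=O)[C@@H]1[C@H]3C(=O)N(c4ccccc4)C(=O)[C@H]3ON12` gives 53.1% in a functional assay, read by spectrophotometry, with a stated time of 2 h, tested at 2.5 mg/mL; on this read-out lower numbers stand for a weaker effect and higher numbers for a stronger effect at the one concentration tested.
Compound 2 `CC(C)[C@@H]1CC[C@@H](C)C[C@@]12N(C)C(=O)[C@@H]1[C@H]3C(=O)N(c4ccc(Cl)cc4)C(=O)[C@H]3ON12` gives 61.3% in this assay.
Compound 3 `COc1ccc(N2C(=O)[C@H]3[C@H](ON4[C@@H]3C(=O)N(C)[C@@]43C[C@H](C)CC[C@H]3C(C)C)C2=O)cc1` gives 59.3% in this assay.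

Compound 3 holds the second highest of the three numbers, yet none of the three stand apart: the gap is a number 2 percentage points lower from compound 2 to compound 3 (within the scatter) and a number 6.2 percentage points higher from compound 1 to compound 3 (within the scatter), both inside the usual scatter of such a read-out.

Compound 4 `Cc1ccc(N2C(=O)[C@H]3[C@H](ON4[C@@H]3C(=O)N(C)[C@@]43C[C@H](C)CC[C@H]3C(C)C)C2=O)c(C)c1` differs from compound 3 in one place: 2,4-dimethylphenyl in place of 4-methoxyphenyl on an amide-type nitrogen in a ring. The steps measured so far all exchange a group on the same aromatic ring and all stay small: a number 8.2 percentage points higher from compound 1 to compound 2 (within the scatter), a number 6.2 percentage points higher from compound 1 to compound 3 (within the scatter) and a number 2 percentage points lower from compound 2 to compound 3 (within the scatter). None of them involves a methyl group, and none places a group at the second ring position that 2,4-dimethylphenyl carries, so the new change is not covered directly. What the three steps do show is that changing the group on this ring, whether to chloro or to methoxy, has moved the read-out by less than the scatter. On that basis the expected step in this assay is none beyond the scatter, with no clear direction, which amounts to a number 2.3 percentage points lower from compound 3 to compound 4 (within the scatter). Compound 4 is therefore estimated at 57%, with a range from 42% to 72%.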

Compound 4, a percentage reported as activity, at one concentration (the size of the read-out at that concentration, not a potency): 65.6%
For compound 4 the middle estimate is 8.6 percentage points below the measured one, within the range that was stated.
By their numbers in this assay, from the lowest: compounds 1, 3, 2 and 4 (each within the scatter of the next, the first and the last beyond it).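

At this amide-type nitrogen in a ring, 2,4-dimethylphenyl is the only group shown with a step from the plain phenyl ring that clears the scatter of this assay, with a number 12.5 percentage points higher from compound 1 to compound 4 (beyond the scatter), although the size of that step is modest. This does not set it apart from the other substituted rings, as the comparisons with them remain within the scatter, at a number 6.3 percentage points higher from compound 3 to compound 4 (within the scatter) and a number 4.3 percentage points higher from compound 2 to compound 4 (within the scatter), so the result separates 2,4-dimethylphenyl from phenyl but not from 4-methoxyphenyl or 4-chlorophenyl. No measurement available here bears on why the read-out differs between these compounds.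

The compounds shown leave open whether a phenyl ring carrying a single methyl group would give a read-out closer to that of compound 1 or that of compound 4, which would show whether both methyl groups are needed for the step. They also leave open how the read-out would respond to an amine or a carboxylic acid on this ring, or to a longer alkyl chain in place of the ring on this nitrogen.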